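A few compounds are considered here, and "the series" means these few. Any claim that something is new, unique, unknown or untested is made for them only; others in the source may bear on it.

Measured in a functional assay on L1210 cells (Mus musculus) for inhibition; on this read-out lower numbers stand for stronger inhibition and higher numbers for weaker inhibition:
- Compound 1 `C=C1[C@@H](O)[C@H](n2cnc3c(N(C)C)nc(N)nc32)O[C@@H]1CO`: > 500000 nM (a limit, not a number)
- Compound 2 `C=C1[C@@H](O)[C@H](n2cnc3c(N)ncnc32)O[C@@H]1CO`: 228000 nM
- Compound 3 `C=C1[C@H](n2cnc3c(N)nc(N)nc32)O[C@H](CO)[C@H]1O`: 8200 nM

Compound 3 has the lowest of the two true numbers, and it lies well beyond the usual scatter from compound 2. It is therefore the best starting point for the next comparison.

Compound 4 `C=C1[C@H](n2cnc3c(N(C)C)nc(N)nc32)O[C@H](CO)[C@H]1O` differs from compound 3 in one place: dimethylamino in place of amino on an aromatic carbon. Going by the values given here, no measured pair of compounds shows this change on its own, so any forecast rests on thin evidence. Among the compounds with values here, the only hint comes from compound 1, which also carries dimethylamino, and its > 500000 nM is a limit. A large upward step in this assay, meaning weaker inhibition, is therefore expected, well beyond the scatter. The expected change is an 8.5-fold higher number from compound 3 to compound 4 (0.93 log units; beyond the scatter). For compound 4 the estimated value is 70000 nM, with an expected range from 12000 nM to 400000 nM.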

Compound 4, half-maximal inhibitory concentration: 454000 nM
The estimate for compound 4 lay 6.5-fold (0.81 log units) below the measured number, and the stated range ends below it.
By their numbers in this assay, from the lowest: compound 3; then compounds 2 and 4 (each within the scatter of the next). At a limit, above all of these: compound 1.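

In this assay, dimethylamino in place of amino on this aromatic carbon, next to the ring nitrogen, gives a 55-fold higher number from compound 3 to compound 4 (1.74 log units; beyond the scatter). Going by these compounds alone, this is the first measured size for the change, and it shows that this position tolerates the swap poorly, with inhibition much weaker than with the amino group. Compound 1 carries dimethylamino too, but it stands at a limit, not a number, so it could not give that size: the limit of > 500000 nM in this assay, at which 1 of the 4 values shown sits.

The swap removes the hydrogen-bond donor and adds carbon together, and the compounds shown cannot tell these two parts apart. Methylamino, or a hydroxyl group, on the same carbon would be the natural way to separate them, and how either would fare in this assay remains open.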